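A tert-Butyl to Cyano Swap on a Shared Core

The compounds below may be only part of what the source reports. "The series", "measured", "known", "first", "only" and "open" are said of these compounds alone.

Of the compounds shown here, three have been tested in a functional assay on HepG2 cells (Homo sapiens) for antiproliferative activity, read by MTT assay, with a stated time of 48 h; on this read-out higher numbers stand for weaker inhibition and lower numbers for stronger inhibition. Compound 1 `O=C1Nc2ccc(-c3ccc(C(F)(F)F)cc3)cc2C1=O` gives 5430 nM. Compound 2 `COc1ccc(-c2ccc3c(c2)C(=O)C(=O)N3c2ccc(OC)cc2)cc1` gives > 10000 nM, which is a limit of the assay and not a number. Compound 3 `COc1ccc(CN2C(=O)C(=O)c3cc(-c4ccc(C(C)(C)C)cc4)ccc32)cc1` gives 4580 nM. Of the two numbers shown, compound 3 and compound 1 sit within the usual scatter of each other, so neither can be set apart from the other on this read-out.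

Compound 4 `COc1ccc(CN2C(=O)C(=O)c3cc(-c4ccc(C#N)cc4)ccc32)cc1` differs from compound 3 in one place: cyano in place of tert-butyl on an aromatic carbon. For the measured compounds named here, no measured pair shows the effect of this change, so the expectation rests on compound 3 alone. The step is expected to be small, with no clear direction beyond the scatter, and the estimate writes it as a 1.2-fold higher number from compound 3 to compound 4 (0.08 log units; within the scatter). Compound 4 is therefore expected to give about 5500 nM, with a range from 2000 nM to 15000 nM.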

Compound 4, half-maximal inhibitory concentration: 890 nM
Compound 4: the middle estimate sits 6.2-fold (0.79 log units) above what was measured; the whole stated range lies above it.
By their numbers in this assay, from the lowest: compound 4; then compounds 3 and 1 (each within the scatter of the next). At a limit, above all of these: compound 2.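

In this assay, for the compounds shown here, cyano in place of tert-butyl gives a 5.1-fold lower number from compound 3 to compound 4 (0.71 log units; beyond the scatter), the first step in this set that lies beyond the scatter. This shows that the read-out responds to what sits at this position, para to a large group, while the rest of compound 3 stays unchanged. The swap changes the number of heavy atoms and adds a hydrogen-bond acceptor at the same time, so this one pair cannot separate the two, and nothing shown here accounts for the step.

Going by these compounds, it remains open how an amine, a carboxylic acid or a methoxy group at this position would compare with cyano. A single pair also leaves open whether the same swap would give a similar step on the core of compound 1.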